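Trading methoxymethoxy for dimethylamino on a carbonyl carbon

The source may hold more compounds than are shown below. What is called first, only, known or untested is meant among the compounds shown, and "the series" means these compounds.

In a functional assay on U-87MG ATCC cells (Homo sapiens) for cytotoxicity, with a stated time of 7 days (on this read-out lower numbers stand for stronger inhibition and higher numbers for weaker inhibition), compound 3 `COCOC(=O)c1ccccc1SC/C=C(\C)CC/C=C(\C)CCC=C(C)C` gives 10000 nM, level with compound 2 `CC(C)=CCC/C(C)=C/CC/C(C)=C/CSc1ccccc1C(N)=O` at 10000 nM. Compound 1 `CNC(=O)c1ccccc1SC/C=C(\C)CC/C=C(\C)CCC=C(C)C` gives 18000 nM, which is within the usual scatter of both, so these three numbers do not separate the compounds.

The next step leads to compound 4 `CC(C)=CCC/C(C)=C/CC/C(C)=C/CSc1ccccc1C(=O)N(C)C`. The structural change is dimethylamino in place of methoxymethoxy on a carbonyl carbon, with dimethylamino in place of methoxymethoxy on a carbonyl carbon.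

For the measured compounds named here, three measured steps bear on this. The closest puts methoxymethoxy in place of methylamino at that same carbon, giving a 1.8-fold lower number from compound 1 to compound 3 (0.26 log units; within the scatter). Methoxymethoxy in place of amino gives no change at the digits printed from compound 2 to compound 3 (within the scatter). Hydrogen in place of methyl on the amide-type nitrogen gives a 1.8-fold lower number from compound 1 to compound 2 (0.26 log units; within the scatter).

All three steps stay inside the scatter, so no step beyond it is expected in this assay. The expected step is a 1.2-fold higher number from compound 3 to compound 4 (0.08 log units; within the scatter). For compound 4 the estimate is 12000 nM, with an expected range of 6000 nM to 25000 nM.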

Compound 4, half-maximal inhibitory concentration: 20000 nM
Beside the measured number, compound 4's estimate is 1.7-fold (0.22 log units) below it; measured number inside the range.
By their numbers in this assay, from the lowest: compounds 2, 3, 1 and 4 (each within the scatter of the next).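

In this assay, dimethylamino on the carbonyl carbon gives a 2.0-fold higher number from compound 3 to compound 4 (0.30 log units; within the scatter) when it replaces methoxymethoxy, and a 2.0-fold higher number from compound 2 to compound 4 (0.30 log units; within the scatter) when it replaces amino. Adding a second methyl to the amide-type nitrogen gives a 1.1-fold higher number from compound 1 to compound 4 (0.05 log units; within the scatter). With this fourth group, every pair among amino, methylamino, dimethylamino and methoxymethoxy on this carbon still lies within the scatter, so this read-out does not tell these four groups apart, and no measured evidence here accounts for the numbers.

Going by these compounds, it remains open whether a carboxylic acid or a larger amine such as morpholine on this carbonyl carbon would give a step beyond the scatter. On these data alone, it also remains open whether a shorter chain in place of the long one in the shared core would do so.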